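Putting 4-methoxypyridin-3-yl on compound 1

The compounds below may be only part of what the source reports. "The series", "measured", "known", "first", "only" and "open" are said of these compounds alone.

Among the compounds with values here, in a functional assay on SJSA-1 cells (Homo sapiens) for antiproliferative activity, with a stated time of 72 h (a higher number here means a weaker inhibitor of growth, a lower number a stronger inhibitor of growth), compound 1 `COc1ccccc1-c1nc2c(n1C(C)C)[C@H](c1ccc(Cl)cc1C)N(c1cc(Cl)ccc1C)C2=O` gives 62 nM, the lower of the two numbers known so far, while compound 2 `COc1ccc(F)cc1-c1nc2c(n1C(C)C)C(c1ccc(Cl)cc1C)N(c1cc(Cl)ccc1C)C2=O` gives 228 nM. Compound 3 `COc1ccncc1-c1nc2c(n1C(C)C)[C@H](c1ccc(Cl)cc1C)N(c1cc(Cl)ccc1C)C2=O` keeps the core of compound 1 and changes one group: 4-methoxypyridin-3-yl in place of 2-methoxyphenyl on an aromatic carbon. Within the data shown here, no measured pair shows this kind of change, so any forecast is loose. A modest move to a higher number in this assay is expected, meaning somewhat weaker growth inhibition. The estimated step is a 1.9-fold higher number from compound 1 to compound 3 (0.29 log units; within the scatter). For compound 3 the expected value is 120 nM, within a range of 40 nM to 400 nM.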

Compound 3, concentration for 50% growth inhibition: 345 nM
For compound 3 the middle estimate is 2.9-fold (0.46 log units) below the measured one, within the range that was stated.
By their numbers in this assay, from the lowest: compound 1; then compounds 2 and 3 (each within the scatter of the next).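

Placing 4-methoxypyridin-3-yl instead of 2-methoxyphenyl on the aromatic carbon between two ring nitrogen atoms gives a 5.6-fold higher number from compound 1 to compound 3 (0.75 log units; beyond the scatter) in this assay and so weakens growth inhibition. The two groups have the same heavy-atom count and differ by one ring carbon exchanged for nitrogen, so this position is sensitive to even this small change. Nothing measured here gives a reason for the loss. Still open, on these data alone, is whether a ring nitrogen elsewhere in this ring has the same effect, and how an ethoxy group or an amine in place of the methoxy would behave.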